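The source may hold more compounds than are shown below. What is called first, only, known or untested is meant among the compounds shown, and "the series" means these compounds.

Values in an assay on HEK293 cells for positive allosteric modulation of metabotropic glutamate receptor 5 (Homo sapiens), read by FLIPR; on this read-out lower numbers stand for an effect already at smaller amounts and higher numbers for an effect only at larger amounts of compound:
compound 1 `O=C(C1CCC2(CCC2)CC1)N1CC(c2nc(-c3cccc(Cl)c3)no2)C1`: 1100 nM
compound 2 `O=C(N1CCC(F)CC1)N1CC(c2nc(-c3cccc(Cl)c3)no2)C1`: 990 nM
compound 3 `O=C(c1ccccc1F)N1CC(c2nc(-c3cccc(Cl)c3)no2)C1`: > 10000 nM, a limit of this assay and not a number

Compound 3 thus sits at the weak end of the set, at the limit (the limit of > 10000 nM in this assay, at which 1 of the 3 values shown sits), with no number of its own. Compound 4 `CC1CCCC(C(=O)N2CC(c3nc(-c4cccc(Cl)c4)no3)C2)C1` carries 3-methylcyclohexyl in place of 2-fluorophenyl on a carbonyl carbon. The measured steps that bear on this change run the opposite way: an at least 9.0-fold higher number from compound 1 to compound 3 (0.95 log units; beyond the scatter) and an at least 10-fold higher number from compound 2 to compound 3 (1.00 log units; beyond the scatter), both beyond the scatter, where a six-membered non-aromatic ring gave way to the aromatic one. Compound 4 returns to a six-membered non-aromatic ring of carbon only, so a reversal of that loss is expected, a step of an at least 8.3-fold lower number from compound 3 to compound 4 (0.92 log units; beyond the scatter). Compound 4 is expected near 1200 nM, in the range 400 nM to 5000 nM.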

Compound 4, half-maximal effective concentration: 410 nM
Compound 4: middle estimate off by 2.9-fold (0.47 log units), on the high side; the range from low to high includes it.
By their numbers in this assay, from the lowest: compound 4; then compounds 2 and 1 (each within the scatter of the next). At a limit, above all of these: compound 3.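

Replacing 2-fluorophenyl with 3-methylcyclohexyl on this carbonyl carbon gives an at least 24-fold lower number from compound 3 to compound 4 (1.38 log units; beyond the scatter), which more than reverses the loss seen with the aromatic ring. The value of compound 3 is a limit and not a number, so this step is only a lower bound: the limit of > 10000 nM in this assay, at which 1 of the 4 values shown sits. Among the non-aromatic groups at this place, a difference beyond the scatter now appears: a 2.4-fold lower number from compound 2 to compound 4 (0.38 log units; beyond the scatter) and a 2.7-fold lower number from compound 1 to compound 4 (0.43 log units; beyond the scatter).

What the methyl group contributes remains open, since plain cyclohexyl is not among the compounds shown. From the compounds shown here alone, whether an amine or a carboxylic acid on the ring would be accepted also remains open.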